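Trimming the amide aryl group in an orexin-2 antagonist series

The source may hold more compounds than are shown below. What is called first, only, known or untested is meant among the compounds shown, and "the series" means these compounds.

Measured compounds:
Compound 1 `Cc1occc1-c1nnc(SCC(=O)Nc2ccc(F)cc2)n1Cc1ccco1`: 158 nM
Compound 2 `Cc1occc1-c1nnc(SCC(=O)Nc2ccc(N(C)C)cc2)n1Cc1ccco1`: 158 nM

Both were tested in a functional assay on CHO cells for antagonist activity at Orexin receptor type 2 (Homo sapiens), read by FLIPR and calcium flux; a lower number here means a stronger inhibitor, a higher number a weaker inhibitor. Compound 1 stands level with compound 2 at the digits shown: the step of no change at the digits printed from compound 1 to compound 2 (within the scatter) lies within the scatter. Compound 3 `Cc1occc1-c1nnc(SCC(N)=O)n1Cc1ccco1` has not been measured. Its change from compound 1 is hydrogen in place of 4-fluorophenyl on an amide-type nitrogen. Going by the values given here, the only measured step, from compound 1 to compound 2, swaps one substituent on the ring for another and leaves the ring in place, so it speaks only indirectly to removing the whole ring. Among the compounds with values here, no measured pair shows what happens when the aryl group itself is taken off. With the amide nitrogen carrying only hydrogens, a loss of inhibitory strength is expected, and the step of a 19-fold higher number from compound 1 to compound 3 (1.28 log units; beyond the scatter) is estimated to be large. For compound 3 the expected value is 3000 nM, with a range from 500 nM to 20000 nM.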

Compound 3, inhibition constant: > 15800 nM
Compound 3 gave a limit, no number (the forecaster's own chance of this, stated with the estimate: 35%); middle value at least 5.2-fold (0.72 log units) from the limit.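

Taking the whole aryl group off the amide nitrogen does what swapping a substituent on that ring did not: it causes a large loss of inhibitory strength. In this assay compound 3 gives only a limit, not a number: the limit of > 15800 nM in this assay, at which 1 of the 3 values shown sits. The loss appears as an at least 100-fold higher number from compound 1 to compound 3 (2.00 log units; beyond the scatter) and equally as an at least 100-fold higher number from compound 2 to compound 3 (2.00 log units; beyond the scatter), so across these three compounds, inhibition depends on an aryl group being on this nitrogen, whether it carries fluoro or dimethylamino.

Still open, as far as these compounds go, is how much of that aryl group is needed, and whether a methyl group, a longer alkyl chain or an unsubstituted phenyl ring on this nitrogen would behave like hydrogen or like the substituted rings. Also open, from the compounds shown here alone, is whether a carboxylic acid on the ring would leave inhibition unchanged, as the swap between fluoro and dimethylamino did.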